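The source may report more compounds than this note shows. Statements on the series, on what has been measured and on what is new or still open speak of the compounds shown alone.

Measured in an ADME assay on BaF3 cells (Mus musculus) for cytotoxicity, read by CellTiter-Glo and CCK-8 assay, with a stated time of 72 h; on this read-out lower numbers stand for stronger inhibition of growth and higher numbers for weaker inhibition of growth:

- Compound 1 `C=CC(=O)Nc1ccc(C(=O)Nc2ccc(C)c(Nc3nccc(-c4cccnc4)n3)c2)cc1`: 5600 nM
- Compound 2 `C=CC(=O)N(CCN(C)C)Cc1ccc(C(=O)Nc2ccc(C)c(Nc3nccc(-c4cccnc4)n3)c2)cc1`: > 10000 nM (a limit)
- Compound 3 `Cc1ccc(NC(=O)c2ccc(CN(CCN(C)C)C(=O)c3cccs3)cc2)cc1Nc1nccc(-c2cccnc2)n1`: > 10000 nM (a limit)

Compound 2 thus has no number, only the limit > 10000 nM. Compound 4 `C=CC(=O)N(CCN(CC)CC)Cc1ccc(C(=O)Nc2ccc(C)c(Nc3nccc(-c4cccnc4)n3)c2)cc1` carries diethylamino in place of dimethylamino on a saturated chain carbon, two bonds along the chain from an amide-type nitrogen. Among the compounds with values here, two measured steps touch compound 2, and neither alters this amine. One is an at least 1.7-fold higher number from compound 1 to compound 2 (0.25 log units; that floor lies within the scatter). The other is a step that the two limits leave unreadable from compound 2 to compound 3. Neither therefore gives a size for the present change, and no step beyond the scatter is expected in this assay. The expected step is a number no higher from compound 2 to compound 4 (the limit leaves the size open). A report as a limit is expected to be more likely than not. For compound 4 the estimate is 10000 nM, with an expected range of 4000 nM to 25000 nM.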

Compound 4, concentration for 50% growth inhibition: 5450 nM
Estimate against measurement, compound 4: 1.8-fold (0.26 log units) above; measured number inside the range.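

In this assay, compound 4, with diethylamino on the saturated chain carbon, gives a measured number, whereas compound 2, with dimethylamino at that place, is reported only as a limit. The change reads as an at least 1.8-fold lower number from compound 2 to compound 4 (0.26 log units; that floor lies within the scatter), so the amine at this place can be varied without losing a readable value, but no true size can be stated. The step remains a floor because compound 2 carries only a limit: the limit of > 10000 nM in this assay, at which 2 of the 4 values shown sit.

From the compounds shown here alone, whether dipropylamino or a primary amine at this place would give a readable value remains open. So does the outcome of a longer chain in place of 2-(diethylamino)ethyl.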